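The compounds below may be only part of what the source reports. "The series", "measured", "known", "first", "only" and "open" are said of these compounds alone.

Compound 1 `N#CC1=C(N)Oc2c(N)cc3nc4ccccc4nc3c2C12C(=O)N(Cc1cnnn1-c1ccc(F)cc1)c1ccccc12` gives > 50000 nM in a functional assay on A549 cells (Homo sapiens) for antiproliferative activity, read by MTT assay, with a stated time of 48 h (a higher number here means a weaker inhibitor, a lower number a stronger inhibitor), which is a limit of the assay. Compound 2 `Cc1ccc(C)c(-n2nncc2CN2C(=O)C3(C(C#N)=C(N)Oc4c(N)cc5nc6ccccc6nc5c43)c3ccccc32)c1` gives > 50000 nM in this assay, again a limit and not a number.

Compound 2 thus stands at the limit, where both values sit (the limit of > 50000 nM in this assay, at which 2 of the 2 values shown sit). Compound 3 `Cc1ccc(-n2nncc2CN2C(=O)C3(C(C#N)=C(N)Oc4c(N)cc5nc6ccccc6nc5c43)c3ccccc32)cc1Cl` differs from compound 2 by 3-chloro-4-methylphenyl in place of 2,5-dimethylphenyl on an aromatic nitrogen. For the measured compounds named here, the one measured step, a step that the two limits leave unreadable from compound 1 to compound 2, also exchanges the group on that aromatic nitrogen, and its size cannot be read. Compound 3 is therefore expected to remain at the limit, with a step that the limit leaves unreadable from compound 2 to compound 3 as the expected step and no change beyond the scatter foreseen. Compound 3 is estimated at 80000 nM, in the range 20000 nM to 300000 nM.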

Compound 3, half-maximal inhibitory concentration: 11800 nM
Compound 3: middle estimate off by 6.8-fold (0.83 log units), on the high side; measured number below the stated range.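

In this assay, 3-chloro-4-methylphenyl on the aromatic nitrogen gives an at least 4.2-fold lower number from compound 2 to compound 3 (0.62 log units; beyond the scatter), and the same group gives an at least 4.2-fold lower number from compound 1 to compound 3 (0.62 log units; beyond the scatter). The exchange at this position can therefore bring a compound with the shared core off the limit, which the earlier pair could not show, since its step cannot be read. Compound 3 is the only one with a number, and the other two remain limits: the limit of > 50000 nM in this assay, at which 2 of the 3 values shown sit.

From the compounds shown here alone, it remains open whether the chlorine alone matters or only its combination with the methyl. Also open, going by these compounds, is what a phenyl bearing an amine or a carboxylic acid would give here.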